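The source may hold more compounds than are shown below. What is called first, only, known or untested is meant among the compounds shown, and "the series" means these compounds.

Compound 3 `Cc1cccc(-c2cn3ccnc3c(-c3ccc4ncn(Cc5ccccc5)c4c3)n2)c1` gives the highest of the three numbers in a functional assay on MDA-MB-231 cells (Homo sapiens) for inhibition, read by sulforhodamine B assay, with a stated time of 48 h, tested at 10 uM (a lower number here means less inhibition, a higher number more inhibition at the concentration tested (going by the name of the read-out)), with 28.4%. Compound 1 `c1ccc2c(-c3cn4ccnc4c(-c4ccc5ncn(C6CCCCC6)c5c4)n3)cccc2c1` gives 20.8%, within the scatter of compound 3, while compound 2 `COc1ccccc1-c1cn2ccnc2c(-c2ccc3ncn(C4CCCCC4)c3c2)n1` gives 15.9%, a gap beyond the scatter. Compound 4 `c1ccc(Cn2cnc3ccc(-c4nc(-c5cccc6ccccc56)cn5ccnc45)cc32)cc1` is not yet measured; it differs from compound 3 by naphthalen-1-yl in place of 3-methylphenyl on an aromatic carbon. Among the compounds with values here, the one measured step at this position, a number 4.9 percentage points lower from compound 1 to compound 2 (within the scatter), was within the scatter, so replacing the group there has so far moved little, and compound 1 already carries the same naphthalen-1-yl. No step beyond the scatter is therefore expected for compound 4, as a number 4.4 percentage points lower from compound 3 to compound 4 (within the scatter) reflects. Compound 4 is estimated to give 24%, likely between 10% and 38%.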

Compound 4, a percentage reported as inhibition, at one concentration (the size of the read-out at that concentration, not a potency): 28.7%
For compound 4 the middle estimate is 4.7 percentage points below the measured one; low and high end bracket the measured number.
By their numbers in this assay, from the lowest: compounds 2, 1, 3 and 4 (each within the scatter of the next, the first and the last beyond it).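

With benzyl held fixed on the aromatic nitrogen, naphthalen-1-yl in place of 3-methylphenyl gives a number 0.3 percentage points higher from compound 3 to compound 4 (within the scatter) in this assay, so this larger group with two aromatic rings produces no step beyond the scatter. The aromatic nitrogen can now be read too: benzyl in place of cyclohexyl gives a number 7.9 percentage points higher from compound 1 to compound 4 (within the scatter). Nothing available explains these results. All groups shown on the aromatic carbon are aromatic rings of carbon, so the effect of an amine or a carboxylic acid there remains open. On these data alone, a longer chain on the aromatic nitrogen also remains open.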